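Exchanging the ring group: compound 3 to compound 4

The compounds below may be only part of what the source reports. "The series", "measured", "known", "first", "only" and "open" are said of these compounds alone.

Measured in an ADME assay on MDCK cells (Canis lupus familiaris) for permeability, in the apical to basolateral direction; a higher number here means that the compound crosses the layer faster, a lower number that the compound crosses the layer more slowly:
- Compound 1 `CC(C)C(/C=C1\NC(=O)NC1=O)c1ccc(-c2ccc3cccc(F)c3c2)[nH]c1=O` gives 12.3 10^-6 cm/s
- Compound 2 `CC(C)C(/C=C1\SC(=O)NC1=O)c1ccc(-c2ccc3cccc(F)c3c2)[nH]c1=O` gives 15.4 10^-6 cm/s
- Compound 3 `CC(C)C(CC1NC(=O)NC1=O)c1ccc(-c2ccc3cccc(F)c3c2)[nH]c1=O` gives 17.1 10^-6 cm/s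

Compound 3 stands within the scatter of both others, with a 1.4-fold higher number from compound 1 to compound 3 (0.14 log units; within the scatter) and a 1.1-fold higher number from compound 2 to compound 3 (0.05 log units; within the scatter). Compound 4 `CC(C)C(/C=C1/C(=O)NC(=O)N1C)c1ccc(-c2ccc3cccc(F)c3c2)[nH]c1=O`, not yet measured, differs from compound 3 by a group of 9 heavy atoms (5 carbon, 2 nitrogen, 2 oxygen; one five-membered non-aromatic ring with 2 hetero atoms) in place of a group of 8 heavy atoms (4 carbon, 2 nitrogen, 2 oxygen; one five-membered non-aromatic ring with 2 hetero atoms), on a saturated chain carbon bound to an aromatic carbon and a saturated chain carbon. The two steps above and a 1.3-fold higher number from compound 1 to compound 2 (0.10 log units; within the scatter) bear on this change, since each exchanges the group at that same place, and all three stay within the scatter. For the measured compounds named here, no measured compound carries the entering group, so this evidence is indirect. The expected outcome is a 1.1-fold lower number from compound 3 to compound 4 (0.03 log units; within the scatter), which would be no step beyond the scatter. For compound 4 the estimated value in this assay is 16 10^-6 cm/s, with an expected range of 9 10^-6 cm/s to 27 10^-6 cm/s.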

Compound 4, apparent permeability: 14.1 10^-6 cm/s
Compound 4: middle estimate off by 1.1-fold (0.05 log units), on the high side, within the range that was stated.
By their numbers in this assay, from the lowest: compounds 1, 4, 2 and 3 (each within the scatter of the next).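

In this assay, for the compounds shown here, methyl in place of hydrogen on an amide-type nitrogen in a ring gives a first direct reading at this group (a 1.1-fold higher number from compound 1 to compound 4 (0.06 log units; within the scatter)), and that change stays within the scatter. The exchanges of the whole group on the saturated chain carbon also stay within it (a 1.2-fold lower number from compound 3 to compound 4 (0.08 log units; within the scatter); a 1.1-fold lower number from compound 2 to compound 4 (0.04 log units; within the scatter)). Nothing measured here accounts for these small steps. Still open, as far as these compounds go, is whether an amine or a carboxylic acid at this place, or a longer chain on that amide-type nitrogen, would give a step beyond the scatter.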